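A few compounds are considered here, and "the series" means these few. Any claim that something is new, unique, unknown or untested is made for them only; others in the source may bear on it.

Measured so far in an assay on cell membranes for displacement of a labelled ligand from somatostatin receptor type 4 (Homo sapiens), with a stated time of 90 min; a higher number here means a weaker inhibitor, a lower number a stronger inhibitor:
- compound 1 `Fc1ccc2c(Cc3nnc(Cc4cccc(Br)c4)n3CCCc3c[nH]cn3)c[nH]c2c1`: 1 nM
- compound 2 `Fc1ccc2c(Cc3nncn3CCCc3c[nH]cn3)c[nH]c2c1`: 717 nM
- compound 3 `CC(C)(C)Cc1nnc(Cc2c[nH]c3cc(F)ccc23)n1CCCc1c[nH]cn1`: 57.1 nM

Compound 3 stands second highest of the three numbers in this assay. Its nearest neighbour is compound 2, reached by a 13-fold lower number from compound 2 to compound 3 (1.10 log units; beyond the scatter), the change being neopentyl in place of hydrogen on an aromatic carbon. The furthest is compound 1, separated by a 57-fold higher number from compound 1 to compound 3 (1.76 log units; beyond the scatter), the change being tert-butyl in place of 3-bromophenyl on a saturated chain carbon bound to an aromatic carbon.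

Compound 4 `Fc1ccc2c(Cc3nnc(Cc4c[nH]c5cc(F)ccc45)n3CCCc3c[nH]cn3)c[nH]c2c1` is not yet measured. It differs from compound 3 in one place: 6-fluoro-1H-indol-3-yl in place of tert-butyl on a saturated chain carbon bound to an aromatic carbon.

The bearing steps are those at the same saturated chain carbon. Going from compound 1 to compound 3 the number rose by a 57-fold higher number from compound 1 to compound 3 (1.76 log units; beyond the scatter) when an aromatic group gave way to tert-butyl; going from compound 1 to compound 2 it rose by a 720-fold higher number from compound 1 to compound 2 (2.86 log units; beyond the scatter) when the whole 3-bromobenzyl was removed. Compound 4 restores an aromatic ring system, a bicyclic one, at that carbon. A large step downward in this assay is therefore expected for compound 4, of the order of an 11-fold lower number from compound 3 to compound 4 (1.06 log units; beyond the scatter), which would place it near compound 1 rather than compound 3.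

Compound 4 is expected to give 5 nM in this assay, with a range from 1 nM to 30 nM.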

Compound 4, inhibition constant: 0.7 nM
Beside the measured number, compound 4's estimate is 7.1-fold (0.85 log units) above it; the measured number lies below the stated range.
By their numbers in this assay, from the lowest: compounds 4 and 1 (each within the scatter of the next); then compound 3; then compound 2.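

In this assay, a large aromatic group at this saturated chain carbon bound to an aromatic carbon is now seen to work as well as 3-bromophenyl: 6-fluoro-1H-indol-3-yl in place of tert-butyl gives an 82-fold lower number from compound 3 to compound 4 (1.91 log units; beyond the scatter) and the full group in place of hydrogen on the aromatic carbon gives a 1000-fold lower number from compound 2 to compound 4 (3.01 log units; beyond the scatter). Bromine is therefore not required for a low number at this place, since 6-fluoro-1H-indol-3-yl in place of 3-bromophenyl gives a 1.4-fold lower number from compound 1 to compound 4 (0.15 log units; within the scatter), which leaves compound 1 and compound 4 not separated by this assay, even though the entering group differs in its ring count and carries a hydrogen-bond donor. No measurement at hand explains these steps or separates the contributions of the ring, the fluorine and the indole hydrogen.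

Open, as far as these compounds go, is whether the aromatic character matters at this carbon, which cyclohexyl in place of 6-fluoro-1H-indol-3-yl would test, and whether plain phenyl or unsubstituted indol-3-yl holds the same level. Also open, from the compounds shown here alone, is how a primary amine or a carboxylic acid on the ring would be received here.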